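This account rests on a few compounds, and the source may have more. Where it says the series, first, only, none or still open, it means among the compounds named here.

Of the compounds shown here, two have been tested in a functional assay on Bel-7402 cells (Homo sapiens) for inhibition, read by sulforhodamine B assay, with a stated time of 72 h, tested at 10 uM; a higher number here means more inhibition at the concentration tested (going by the name of the read-out), a lower number less inhibition. Compound 1, `C[C@H](Nc1nc(N)nc(N)c1C#N)c1nn(-c2cccc(S(C)(=O)=O)c2)c2cc(F)ccc12`, gives in this assay a value of 14%. Compound 2, `C[C@H](Nc1ncnc2[nH]cnc12)c1nn(-c2cccc(F)c2)c2cc(F)ccc12`, differs from compound 1 both in the amine attached to the shared core and in the aryl group on the aromatic nitrogen, and in this assay compound 2 gives -17%. For the measured compounds named here, compound 2 thus stands lowest of the two numbers measured so far, and the gap to compound 1 is beyond the usual scatter of this kind of measurement.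

Compound 3, `C[C@H](Nc1ncnc2[nH]cnc12)c1nn(-c2cccnc2)c2cc(F)ccc12`, is the next compound to be measured in this assay. It differs from compound 2 in a single place: pyridin-3-yl in place of 3-fluorophenyl on an aromatic nitrogen. Going by the values given here, no pair of measured compounds isolates a change of this kind, so the two numbers at hand say nothing direct about it. The step expected from compound 2 to compound 3 in this assay is small, a number 12 percentage points higher from compound 2 to compound 3 (beyond the scatter), and is not expected to go beyond the scatter in either direction. For compound 3 in this assay the estimated value is -5%, expected to lie between -25% and 15%.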

Compound 3, a percentage reported as inhibition, at one concentration (the size of the read-out at that concentration, not a potency): 8%
Estimate against measurement, compound 3: 13 percentage points below; the measured number falls inside the stated range.
By their numbers in this assay, from the lowest: compound 2; then compounds 3 and 1 (each within the scatter of the next).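

In this assay, putting pyridin-3-yl in place of 3-fluorophenyl on an aromatic nitrogen gives a number 25 percentage points higher from compound 2 to compound 3 (beyond the scatter). This is the only step shown that isolates this position, and with the amine on the shared core held constant, it shows that the aryl group alone can move the read-out beyond the scatter. The entering ring has one heavy atom fewer and one hydrogen-bond acceptor where the leaving ring has none, but no accompanying data indicate which of these differences matters for the step.

The compounds shown do not separate the gain of the ring nitrogen from the loss of the fluorine, a question that an unsubstituted phenyl group at this position would address, and they do not show whether a pyridin-4-yl group would behave like pyridin-3-yl. As far as these compounds go, how the amine on the shared core acts on its own also remains open, as compound 1 differs from compound 2 in two places and so gives no single-place comparison.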